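Three Hydroxyphenyl Pyridines, All Beyond the Assay Limit

The source may hold more compounds than are shown below. What is called first, only, known or untested is meant among the compounds shown, and "the series" means these compounds.

Compound 1 `Oc1cccc(-c2cc(-c3ccoc3)cc(-c3ccccc3O)n2)c1` is tested in a functional assay on HCT-15 cells (Homo sapiens) for cytotoxicity, read by CCK-8 assay (a higher number here means a weaker inhibitor, a lower number a stronger inhibitor), and gives > 50000 nM, which is a limit of the assay rather than a number. Compound 2 `Oc1ccc(-c2cc(-c3ccoc3)cc(-c3ccccc3O)n2)cc1` gives in this assay > 50000 nM, again a limit. Compound 3 `Oc1cccc(-c2cc(-c3ccccn3)cc(-c3ccccc3O)n2)c1` gives in this assay > 50000 nM, also a limit. The change 4-hydroxyphenyl in place of 3-hydroxyphenyl on an aromatic carbon thus yields a step that the two limits leave unreadable from compound 1 to compound 2. The two cores differ by pyridin-2-yl in place of furan-3-yl on an aromatic carbon, which yields a step that the two limits leave unreadable from compound 1 to compound 3. Compound 4 `Oc1ccc(-c2cc(-c3ccccn3)cc(-c3ccccc3O)n2)cc1` is not yet measured; it carries the same kind of change, (4-hydroxyphenyl in place of 3-hydroxyphenyl on an aromatic carbon), though here the place is meta to a pyridin-2-yl group rather than meta to a furan-3-yl group. For the measured compounds named here, because of the limit of > 50000 nM in this assay, at which 3 of the 3 values shown sit, the expected step is a step that the limit leaves unreadable from compound 3 to compound 4, with nothing among the measured compounds pointing to a readable gain. Compound 4 is therefore estimated at 80000 nM in this assay, with the limit the likeliest outcome.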

Compound 4, half-maximal inhibitory concentration: > 50000 nM
Compound 4 ended at the assay's limit; the forecaster's own chance of this, stated with the estimate: 85%; the middle value does not contradict the limit.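

No step from compound 2 or compound 3 to compound 4 can be read, as each pair ends at the same limit: the limit of > 50000 nM in this assay, at which 4 of the 4 values shown sit.

On these data alone, whether either change alters activity in this assay stays open, as does how far past the limit each compound lies.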